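Naphthalenyl for formylphenyl on the imidazopyrazine core

A few compounds are considered here, and "the series" means these few. Any claim that something is new, unique, unknown or untested is made for them only; others in the source may bear on it.

Measured so far:
- compound 1, `O=Cc1ccc(-c2cn3ccnc3c(-c3ccc4ncn(C5CCCCC5)c4c3)n2)cc1`: 17.5%
- compound 2, `c1ccc2c(-c3cn4ccnc4c(-c4ccc5ncn(C6CCCCC6)c5c4)n3)cccc2c1`: 4.11%
- compound 3, `O=Cc1ccc(-c2cn3ccnc3c(-c3ccc4ncn(Cc5ccccc5)c4c3)n2)cc1`: 17.5%

All three numbers come from a functional assay on HT-29 cells (Homo sapiens) for inhibition, read by sulforhodamine B assay, with a stated time of 48 h, tested at 10 uM; a lower number here means less inhibition, a higher number more inhibition at the concentration tested (going by the name of the read-out). Compound 1 and compound 3 stand level at the digits printed, and together they hold the highest of the three values; compound 2 sits well under both.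

The two cores differ in one place: benzyl in place of cyclohexyl on an aromatic nitrogen. That exchange brings no change at the digits printed from compound 1 to compound 3 (within the scatter), so the two cores behave alike in this assay as far as these data go.

Compound 4, `c1ccc(Cn2cnc3ccc(-c4nc(-c5cccc6ccccc56)cn5ccnc45)cc32)cc1`, is not yet measured. It is derived from compound 3 by naphthalen-1-yl in place of 4-formylphenyl on an aromatic carbon. The same change has been made once before in the series, from compound 1 to compound 2: naphthalen-1-yl in place of 4-formylphenyl on an aromatic carbon. The two place descriptions agree word for word, so it is the same change on two cores that have so far given the same number. That earlier step gave a number 13.4 percentage points lower from compound 1 to compound 2 (beyond the scatter), a modest drop that lies beyond the scatter.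

Because compound 1 fell by a number 13.4 percentage points lower from compound 1 to compound 2 (beyond the scatter) and compound 3 starts from the same level, compound 4 is expected to show a step of about a number 13 percentage points lower from compound 3 to compound 4 (beyond the scatter) in this assay. One prior example is a thin base, so the expected range is kept wide. The estimate for compound 4 in this assay is 4.5%, expected to fall between -6% and 15%.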

Compound 4, a percentage reported as inhibition, at one concentration (the size of the read-out at that concentration, not a potency): 18.6%
Compound 4: middle estimate off by 14.1 percentage points, on the low side; measured number outside the range, above it.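

In this assay, naphthalen-1-yl in place of 4-formylphenyl gives a number 1.1 percentage points higher from compound 3 to compound 4 (within the scatter), so the drop seen on the core bearing cyclohexyl does not carry over to the core bearing benzyl: the same change on two cores in this assay, a number 13.4 percentage points lower (beyond the scatter) from compound 1 to compound 2 and a number 1.1 percentage points higher (within the scatter) from compound 3 to compound 4, 14.5 percentage points apart, beyond the scatter of two such steps. Read along the other edge of the same four compounds, benzyl in place of cyclohexyl gives a number 14.5 percentage points higher from compound 2 to compound 4 (beyond the scatter) when naphthalen-1-yl is present, while it made no difference with 4-formylphenyl present: the same change on two cores in this assay, no change at the digits printed (within the scatter) from compound 1 to compound 3 and a number 14.5 percentage points higher (beyond the scatter) from compound 2 to compound 4, 14.5 percentage points apart, beyond the scatter of two such steps. This shows that, in these four compounds, the outcome of each change depends on the group at the other place, so a step measured on one core is no safe guide to the other; it does not show why, and it rests on a single set of four compounds read at one concentration, which says nothing about potency.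

The compounds shown leave open whether a phenyl ring carrying an amine or a carboxylic acid in place of the formyl group would follow the pattern of compound 1 and compound 3 on both cores. They also leave open whether a longer alkyl chain on the aromatic nitrogen would behave like cyclohexyl or like benzyl when paired with naphthalen-1-yl.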